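Working notes on compounds 1 to 3

This account rests on a few compounds, and the source may have more. Where it says the series, first, only, none or still open, it means among the compounds named here.

Compound 1 `COc1ccc(S(=O)(=O)NN2C(=S)S/C(=C\c3ccc(Cl)c(Cl)c3)C2O)cc1` and compound 2 `O=C1/C(=C/c2ccccc2F)SC(=S)N1NS(=O)(=O)c1ccccc1` have both been run in a functional assay on HFF cells (Homo sapiens) for cytotoxicity; on this read-out higher numbers stand for weaker inhibition and lower numbers for stronger inhibition. For compound 1 the result is only a limit, > 100000 nM. For the measured compounds named here, for compound 2 likewise only a limit is reported, > 100000 nM; compound 2 thus stands at the same limit as the one other value shown, with no number to separate them. From the compounds shown here alone, compound 3 `Cc1ccc(/C=C2\SC(=S)N(NS(=O)(=O)c3ccccc3)C2=O)cc1C` is untested and differs from compound 2 by 3,4-dimethylphenyl in place of 2-fluorophenyl on a double-bonded chain carbon bound to a double-bonded ring carbon. Going by the values given here, no measured step connects any two compounds here. For compound 3 the expected step that the limit leaves unreadable from compound 2 to compound 3 is none beyond the scatter, because both shown values rest at the limit of > 100000 nM in this assay, at which 2 of the 2 values shown sit. Compound 3 is estimated at 150000 nM, within 50000 nM to 500000 nM, most likely again only a limit.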

Compound 3, half-maximal inhibitory concentration: > 100000 nM
Compound 3 ended at the assay's limit; the forecaster's own chance of this, stated with the estimate: 85%; the middle value lies beyond the limit too.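

For the compounds shown here, no step from compound 2 to compound 3 can be read in this assay: the limit of > 100000 nM in this assay, at which 3 of the 3 values shown sit. The compounds shown leave open whether 3,4-dimethylphenyl and 2-fluorophenyl differ at all, and at what concentration any of these compounds would inhibit.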